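A few compounds are considered here, and "the series" means these few. Any claim that something is new, unique, unknown or untested is made for them only; others in the source may bear on it.

Compound 1 `Cc1ccc(S(=O)(=O)N[C@@H](CC(=O)NC(C)(C)C)C(=O)NCCNC(=O)Nc2ccccc2)cc1` — in an ADME assay on HepG2 cells (Homo sapiens) for cytotoxicity (on this read-out lower numbers stand for an effect already at smaller amounts and higher numbers for an effect only at larger amounts of compound), compound 1 gives the assay limit > 11000 nM.
Compound 2 `Cc1ccc(S(=O)(=O)N[C@@H](CC(=O)NC(C)(C)C)C(=O)NCCNC(=O)c2ccccc2Cl)cc1` — in this assay compound 2 gives the assay limit > 11000 nM.

Compound 2 thus stands at the limit of > 11000 nM in this assay, at which 2 of the 2 values shown sit, so only a limit and no number is known for it. Compound 3 `Cc1ccc(S(=O)(=O)N[C@@H](CC(=O)NC(C)(C)C)C(=O)NCCNC(=O)c2ccc(Cl)cc2)cc1` differs from compound 2 by 4-chlorophenyl in place of 2-chlorophenyl on a carbonyl carbon. Going by the values given here, the one measured step at this position, a step that the two limits leave unreadable from compound 1 to compound 2, is unreadable, so no step beyond the scatter can be foreseen. The step that the limit leaves unreadable from compound 2 to compound 3 is expected to stay within the scatter. Compound 3 is therefore estimated at 15000 nM, between 8000 nM and 40000 nM.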

Compound 3, half-maximal effective concentration: > 11000 nM
Compound 3: no number, only a limit (the forecaster's own chance of this, stated with the estimate: 80%); the middle value lies beyond the limit too.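

No step can be read among compound 1, compound 2 and compound 3, because all three give only a limit and no number: the limit of > 11000 nM in this assay, at which 3 of the 3 values shown sit.

From the compounds shown here alone, whether anilino, 2-chlorophenyl or 4-chlorophenyl on the carbonyl carbon makes any difference in this assay stays open.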